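The compounds below may be only part of what the source reports. "The series", "measured", "known", "first", "only" and "open" are said of these compounds alone.

The two measured compounds, and the one still to be made up on numbers, were compared in a functional assay on 143B cells (Homo sapiens) for antiproliferative activity, read by MTT assay, with a stated time of 48 h; a higher number here means a weaker inhibitor, a lower number a stronger inhibitor.

Compound 1 `Cc1cccc(C(=O)Nc2cccc(/C=C/C(=O)c3nc4ccccc4[nH]3)c2)c1` gives 4880 nM.
Compound 2 `COc1cccc(C(=O)Nc2cccc(/C=C/C(=O)c3nc4ccccc4[nH]3)c2)c1` gives 4610 nM.
Compound 3 `Cc1cc(C)cc(C(=O)Nc2cccc(/C=C/C(=O)c3nc4ccccc4[nH]3)c2)c1` has not yet been measured.

Within the data shown here, compound 2 holds the lower of the two numbers so far, but its only neighbour is compound 1, and the step of a 1.1-fold lower number from compound 1 to compound 2 (0.02 log units; within the scatter) lies within the scatter, so the two cannot be told apart on these data. The change to be judged is 3,5-dimethylphenyl in place of 3-methoxyphenyl on a carbonyl carbon. Among the measured compounds shown here, one measured step bears on it: a 1.1-fold lower number from compound 1 to compound 2 (0.02 log units; within the scatter), which exchanged methyl for methoxy on an aromatic carbon and moved the number hardly at all. For the measured compounds named here, compound 3 carries the methyl of compound 1 together with a further methyl, and no measured step shows what that further methyl does. Going by the values given here, with the one relevant step flat, the expected step is a 1.0-fold higher number from compound 2 to compound 3 (0.02 log units; within the scatter), that is, nothing beyond the scatter, with a wide range to cover the untested part. Compound 3 is expected at 4800 nM in this assay, between 2000 nM and 12000 nM.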

Compound 3, half-maximal inhibitory concentration: 4020 nM
For compound 3 the middle estimate is 1.2-fold (0.08 log units) above the measured one; the measured number falls inside the stated range.
By their numbers in this assay, from the lowest: compounds 3, 2 and 1 (each within the scatter of the next).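

In this assay, putting 3,5-dimethylphenyl in place of 3-methoxyphenyl on a carbonyl carbon gives a 1.1-fold lower number from compound 2 to compound 3 (0.06 log units; within the scatter), so removing the one hydrogen-bond acceptor of this group, an oxygen, and having only carbon in its eight heavy atoms does not separate the two compounds on these data. The earlier compounds shown here also left the effect of a further methyl unknown, and adding one on an aromatic carbon gives a 1.2-fold lower number from compound 1 to compound 3 (0.08 log units; within the scatter), so this addition likewise leaves the number within the scatter. Across these three compounds, the aromatic ring attached to the carbonyl carbon has accepted methyl, methoxy and two methyl groups without a readable change, and no measurement offered here explains that flatness.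

What remains open is whether any group on this ring can move the number beyond the scatter, since methyl and methoxy are the only groups shown there. An amine, a carboxylic acid or a longer chain such as butyl would test this more strongly, and the shared core stays unchanged throughout, so these compounds say nothing about changes elsewhere.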